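From thiophene vinyl to chloroindole on the sulfonyl sulfur

A few compounds are considered here, and "the series" means these few. Any claim that something is new, unique, unknown or untested is made for them only; others in the source may bear on it.

Measured in an in vivo ADME assay on the whole organism (strain Sprague-Dawley) for pharmacokinetics, with Rattus norvegicus as the target; a lower number here means that a smaller share of the oral dose reaches the circulation, a higher number that a larger share of the oral dose reaches the circulation:
Compound 1 `O=C1[C@@H](NS(=O)(=O)c2ccc3cc(Cl)ccc3c2)CCN1c1ccc2c(c1)CCNC2`: 24%
Compound 2 `O=C1[C@@H](NS(=O)(=O)c2ccc3c(Cl)c[nH]c3c2)CCN1c1ccc2c(c1)CCNC2`: < 1%
Compound 3 `O=C1[C@@H](NS(=O)(=O)/C=C/c2ccc(Cl)s2)CCN1c1ccc2c(c1F)CCNC2`: 68%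

Of the two actual numbers in this small set, the higher belongs to compound 3 at 68%. Compound 1 stands at 24%, a gap beyond the usual scatter. Compound 2 reports < 1%, which is a limit and not a number.

The next compound to be tested is compound 4 `O=C1[C@@H](NS(=O)(=O)c2ccc3c(Cl)c[nH]c3c2)CCN1c1ccc2c(c1F)CCNC2`, which keeps the core of compound 3 and changes the group on the sulfonyl sulfur: 3-chloro-1H-indol-6-yl in place of 2-(5-chlorothiophen-2-yl)ethenyl on a sulfonyl sulfur. In words, 3-chloro-1H-indol-6-yl stands in place of 2-(5-chlorothiophen-2-yl)ethenyl on a sulfonyl sulfur. Going by the values given here, no measured pair of compounds isolates this change, so the expectation rests on a single neighbour. Compound 2 carries the same 3-chloro-1H-indol-6-yl on a different core and gives < 1%, again a limit. Compound 4 thus joins the core of the best measured compound to the group of the poorest, and a fall beyond the scatter is expected, with a number 56 percentage points lower from compound 3 to compound 4 (beyond the scatter) as the estimated step. For compound 4 the estimated value in this assay is 12%, with an expected range from 2% to 35%.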

Compound 4, oral bioavailability: 7%
Compound 4: middle estimate off by 5 percentage points, on the high side; low and high end bracket the measured number.
By their numbers in this assay, from the lowest: compound 4; then compound 1; then compound 3. At a limit, below all of these: compound 2.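

In this assay, the group on the sulfonyl sulfur can now be read on a single core, with a number 61 percentage points lower from compound 3 to compound 4 (beyond the scatter), so on this core 3-chloro-1H-indol-6-yl gives a far smaller oral share than 2-(5-chlorothiophen-2-yl)ethenyl. The set also gains a pair that isolates fluoro in place of hydrogen on an aromatic carbon, with a number at least 6 percentage points higher from compound 2 to compound 4 (that floor lies within the scatter), which shows no gain from the fluoro beyond the scatter. That pair starts from a limit and not a number, so the true size of the step stays unknown, as compound 2 stands at such a limit: the limit of < 1% in this assay, at which 1 of the 4 values shown sits.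

The compounds shown leave open how other groups on the sulfonyl sulfur, such as a plain phenyl or a longer chain ending in a carboxylic acid, would fare on the core of compound 3. They also hold no partner of compound 3 with hydrogen in place of the fluoro, so what the fluoro contributes alongside 2-(5-chlorothiophen-2-yl)ethenyl remains unresolved.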